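From Bromo to Dimethylamino on the Shared Core

The source may report more compounds than this note shows. Statements on the series, on what has been measured and on what is new or still open speak of the compounds shown alone.

In a functional assay on MCF7 cells (Homo sapiens) for cytotoxicity, read by MTT assay, with a stated time of 24 h (a lower number here means a stronger inhibitor, a higher number a weaker inhibitor), compound 2 (`C/C(=N\NC(=O)/C(C#N)=C/c1ccc(Br)cc1)c1c(O)c2ccc(O)cc2oc1=O`) gives 9850 nM and compound 1 (`COc1ccc(/C=C(\C#N)C(=O)N/N=C(\C)c2c(O)c3ccc(O)cc3oc2=O)cc1`) gives 8940 nM. These two numbers lie within the scatter of each other, so neither compound can be ranked above the other.

Compound 3 (`C/C(=N\NC(=O)/C(C#N)=C/c1ccc(N(C)C)cc1)c1c(O)c2ccc(O)cc2oc1=O`) has not yet been measured. It differs from compound 2 by dimethylamino in place of bromo on an aromatic carbon, para to a large group: dimethylamino in place of bromo on an aromatic carbon.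

Among the compounds with values here, one measured step bears on this change, at the same aromatic carbon: bromo in place of methoxy gave a 1.1-fold higher number from compound 1 to compound 2 (0.04 log units; within the scatter). That single exchange did not move the number beyond the scatter. Within the data shown here, it is thin evidence, however, and no measured compound yet shows how dimethylamino behaves in this assay. With nothing pointing in either direction, no shift beyond the scatter is expected. The expected step is a 1.0-fold lower number from compound 2 to compound 3 (0.02 log units; within the scatter). Compound 3 is estimated at 9400 nM, with an expected range of 4500 nM to 19000 nM.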

Compound 3, half-maximal inhibitory concentration: 3420 nM
Compound 3: middle estimate off by 2.7-fold (0.44 log units), on the high side, and the stated range ends above it.
By their numbers in this assay, from the lowest: compound 3; then compounds 1 and 2 (each within the scatter of the next).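

In this assay the group on this aromatic carbon, para to a large group, can move the number beyond the scatter, which the exchange of methoxy and bromo had not shown: dimethylamino in place of bromo gives a 2.9-fold lower number from compound 2 to compound 3 (0.46 log units; beyond the scatter) and dimethylamino in place of methoxy gives a 2.6-fold lower number from compound 1 to compound 3 (0.42 log units; beyond the scatter) so the change holds from both starting points. Within the data shown here, both steps are modest, but they make dimethylamino the one group of the three that stands apart on the shared core, while bromo and methoxy remain within the scatter of each other. No measurement shown here accounts for this shift.

The compounds shown leave open whether the effect belongs to dimethylamino alone or extends to related groups at this carbon, such as a primary amine or diethylamino. They also leave open whether a hydroxyl or a carboxylic acid in the same place would stay level with bromo and methoxy or follow dimethylamino, and whether the step would persist with a change elsewhere on the shared core.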